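A few compounds are considered here, and "the series" means these few. Any claim that something is new, unique, unknown or untested is made for them only; others in the source may bear on it.

The study concerns a toxicity read-out, a toxicity assay on THP-1 cells (Homo sapiens) for inhibition; on this read-out lower numbers stand for higher toxicity in this test and higher numbers for lower toxicity in this test. Three measured compounds share one core and differ only in the group on the carbonyl carbon. Compound 1 is `CCC(=O)Nc1ncc(-c2ccc(OC)cc2)n1C` with an ethyl group there. Compound 2 is `COc1ccc(-c2cnc(NC(=O)c3ccccc3F)n2C)cc1` with a 2-fluorophenyl group, and compound 3 is `COc1ccc(-c2cnc(NC(=O)c3ccc(C)cc3)n2C)cc1` with a 4-methylphenyl group. In this assay compound 1 gives only a limit of > 100000 nM. Compound 2 likewise gives only a limit of > 100000 nM. Compound 3 also reaches only a limit of > 100000 nM. Because the limit of > 100000 nM in this assay, at which 3 of the 3 values shown sit, none of the three steps can be read as a size: a step that the two limits leave unreadable from compound 1 to compound 2, a step that the two limits leave unreadable from compound 1 to compound 3 and a step that the two limits leave unreadable from compound 2 to compound 3. Compound 3 thus stands where the other two stand, at a limit and not at a number.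

Compound 4 is `COc1ccc(-c2cnc(NC(=O)c3ccccc3OC)n2C)cc1` and differs from compound 3 in one place: 2-methoxyphenyl in place of 4-methylphenyl on a carbonyl carbon. The step that bears on this most directly is the exchange of one aryl group for another on the same carbonyl carbon, namely a step that the two limits leave unreadable from compound 2 to compound 3, whose size the limits hide. Going by the values given here, no measured step gives a direction, and no step beyond the scatter is expected in this assay. Compound 4 is therefore expected to give a value near 100000 nM, within 50000 nM to 300000 nM and most probably again a limit. The step of a number no higher from compound 3 to compound 4 (the limit leaves the size open) is expected to be small.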

Compound 4, half-maximal cytotoxic concentration: > 100000 nM
Compound 4 gave a limit, no number; the forecaster's own chance of this, stated with the estimate: 85%; the middle value lies on the limit itself.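

In this assay compound 4 also gives only a limit, > 100000 nM. Going by these compounds alone, no step linking compound 4 to compound 1, compound 2 or compound 3 can be read as a size, because all four sit at the same limit: the limit of > 100000 nM in this assay, at which 4 of the 4 values shown sit. The compounds shown leave open whether any group on the carbonyl carbon would give a measurable number in this assay.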